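Swapping the Bromophenyl for Difluorophenyl: Cytotoxicity Outlook

A few compounds are considered here, and "the series" means these few. Any claim that something is new, unique, unknown or untested is made for them only; others in the source may bear on it.

Compound 1 `CCOC(=O)c1cc(-c2cccc(OCc3cccc(Br)c3)c2)on1` is one of three close relatives examined for toxicity toward cultured cells. In an ADME assay on Vero cells (Chlorocebus sabaeus) for cytotoxicity, with a stated time of 72 h (a lower number here means a stronger inhibitor, a higher number a weaker inhibitor), compound 1 gives > 128000 nM, which is a limit of the assay rather than a number. Compound 2 `CCOC(=O)c1cc(-c2cccc(OCc3cccc(C#N)c3)c2)on1` carries cyano in place of bromo on an aromatic carbon. In this assay compound 2 gives > 128000 nM, again a limit. Compound 3 `CCOC(=O)c1cc(-c2cccc(OCc3ccccc3[N+](=O)[O-])c2)on1` carries 2-nitrophenyl in place of 3-bromophenyl on a saturated chain carbon bound to an oxygen on an aromatic ring. In this assay compound 3 gives > 128000 nM, also a limit. Consequently the steps a step that the two limits leave unreadable from compound 1 to compound 2, a step that the two limits leave unreadable from compound 1 to compound 3 and a step that the two limits leave unreadable from compound 2 to compound 3 cannot be sized, and the whole of the evidence is the limit of > 128000 nM in this assay, at which 3 of the 3 values shown sit.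

Compound 4 `CCOC(=O)c1cc(-c2cccc(OCc3c(F)cccc3F)c2)on1` is not yet measured. It differs from compound 1 as follows: 2,6-difluorophenyl in place of 3-bromophenyl on a saturated chain carbon bound to an oxygen on an aromatic ring. Because compound 1 sits at > 128000 nM, and the two neighbours sit at the same limit, no step beyond the scatter is expected. The expected step is therefore a step that the limit leaves unreadable from compound 1 to compound 4, meaning a value most likely reported again only as a limit. For compound 4 the expected value is 150000 nM, with a range from 100000 nM to 300000 nM.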

Compound 4, half-maximal inhibitory concentration: > 128000 nM
Compound 4: only a limit was reported; the forecaster's own chance of this, stated with the estimate: 85%; the middle value does not contradict the limit.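

Among the compounds shown here, compound 4 is again reported only as a limit, as are compound 1, compound 2 and compound 3, so no step from any of them to compound 4 can be read: the limit of > 128000 nM in this assay, at which 4 of the 4 values shown sit. The compounds shown leave open how far apart these four really lie in this assay, and whether any group on the saturated chain carbon would give a readable value.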